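Carboxy for hexyloxy at the aromatic oxygen position

A few compounds are considered here, and "the series" means these few. Any claim that something is new, unique, unknown or untested is made for them only; others in the source may bear on it.

Within the pair measured so far, compound 2 `CCCCCCOc1ccc(-c2oc3ccc(C(=O)O)cc3c(=O)c2O)cc1` stands lowest: in a functional assay on the whole organism (stomach) for inhibition, with Rattus norvegicus as the target, at a dose of 80 mg/kg (a lower number here means less inhibition, a higher number more inhibition at the dose given (going by the name of the read-out)), compound 2 gives -11%, while compound 1 `COc1ccc(-c2oc3ccc(C(=O)O)cc3c(=O)c2O)cc1` gives 24%. Within the data shown here, the one measured step, a number 35 percentage points lower from compound 1 to compound 2 (beyond the scatter), runs along the chain that compound 3 `O=C(O)c1ccc(-c2oc3ccc(C(=O)O)cc3c(=O)c2O)cc1` now loses: carboxy in place of hexyloxy on an aromatic carbon. Among the measured compounds shown here, that step bears on the change only in part, since carboxy has no precedent here. Removing the chain is expected to recover ground, so a rise of about a number 26 percentage points higher from compound 2 to compound 3 (beyond the scatter) is estimated, with wide uncertainty. Compound 3 is expected at 15%, between -15% and 45%.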

Compound 3, a percentage reported as inhibition, in the whole organism at one dose (the size of the read-out at that dose, not a potency): 23%
Compound 3: the middle estimate sits 8 percentage points below what was measured; measured number inside the range.
By their numbers in this assay, from the lowest: compound 2; then compounds 3 and 1 (each within the scatter of the next).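

In this assay, carboxy in place of hexyloxy on an aromatic carbon is a large step (a number 34 percentage points higher from compound 2 to compound 3 (beyond the scatter)), so the low number of compound 2 does not carry over once the hexyloxy chain is gone. Carboxy in place of methoxy at this place (a number 1 percentage points lower from compound 1 to compound 3 (within the scatter)) stays within the scatter, so methoxy and carboxy cannot be told apart here at this dose. Nothing at hand explains either step.

Open, from the compounds shown here alone, is whether a butoxy chain here would read closer to compound 1 or to compound 2. Also open, going by these compounds, is whether an amine at this place would match compound 3.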